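The source may report more compounds than this note shows. Statements on the series, on what has been measured and on what is new or still open speak of the compounds shown alone.

Compound 2 `O=C(O)c1cccc(-c2csc(Nc3ccccc3)n2)c1` in an ADME assay on microsomes from liver (Homo sapiens) for metabolic stability, read by LC-MS, using NADPH (on this read-out higher numbers stand for a longer-lived compound and lower numbers for a shorter-lived compound), gives 1.43 h. Compound 1 `O=C(O)c1cccc(-c2csc(Nc3ccccc3F)n2)c1` carries fluoro in place of hydrogen on an aromatic carbon and in this assay gives 1.61 h, a step of a 1.1-fold higher number from compound 2 to compound 1 (0.05 log units; within the scatter). Compound 3 `O=C(O)c1cccc(-c2cnc(Nc3ccccc3F)o2)c1` sits on a different core; the difference between the two cores is not broken down here. In this assay compound 3 gives 4.32 h, the highest of the three. Compound 4 `O=C(O)c1cccc(-c2cnc(Nc3ccc(F)cc3F)o2)c1` carries, relative to compound 3, (fluoro in place of hydrogen on an aromatic carbon), a change of the same kind as that from compound 2 to compound 1, though here the place is meta to a fluoro group and para to a large group rather than ortho to a large group. For compound 4 the expected step is a 1.1-fold higher number from compound 3 to compound 4 (0.03 log units; within the scatter). This rests on compound 1, because a 1.1-fold higher number from compound 2 to compound 1 (0.05 log units; within the scatter) stayed within the scatter. Compound 4 is therefore estimated at 4.6 h, between 2.4 h and 9 h.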

Compound 4, half-life: 4.65 h
The estimate for compound 4 lay 1.0-fold (0.00 log units) below the measured number; low and high end bracket the measured number.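

In this assay the step for fluoro in place of hydrogen on the core of compound 3 reads a 1.1-fold higher number from compound 3 to compound 4 (0.03 log units; within the scatter). Set beside the same change on the core of compound 1, the two steps do not differ: the same change on two cores in this assay, a 1.1-fold higher number (0.05 log units; within the scatter) from compound 2 to compound 1 and a 1.1-fold higher number (0.03 log units; within the scatter) from compound 3 to compound 4, 1.0-fold (0.02 log units) apart, within the scatter of two such steps. Among the compounds shown here, this shows that the change left the half-life within the scatter on both cores, but it rests on only two pairs, with the fluoro at a different place on the ring in each, and it does not show that the same would hold on any further core.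

The compounds shown leave open whether a chloro or methoxy group at these places would behave like fluoro. They also leave open whether an amide in place of the carboxylic acid would alter the half-life.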